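Moving the nitrile on the pendant phenyl of compound 3

The compounds below may be only part of what the source reports. "The series", "measured", "known", "first", "only" and "open" are said of these compounds alone.

Measured compounds:
Compound 1, `CN(C)CCCCOC(=O)Nc1ccc(Cn2nc(-c3ccccc3)c3ccccc3c2=O)cc1`, in an ADME assay on Huh-7 cells (Homo sapiens) for cytotoxicity, read by MTT assay, with a stated time of 48 h (on this read-out lower numbers stand for higher toxicity in this test and higher numbers for lower toxicity in this test), gives 16000 nM.
Compound 2, `COc1ccc(-c2nn(Cc3ccc(NC(=O)OCCCCN(C)C)cc3)c(=O)c3ccccc23)cc1`, in this assay gives 20300 nM.
Compound 3, `CN(C)CCCCOC(=O)Nc1ccc(Cn2nc(-c3ccc(C#N)cc3)c3ccccc3c2=O)cc1`, in this assay gives 37000 nM.

For the measured compounds named here, compound 3 has the highest number of the three in this assay, but only the step of a 2.3-fold higher number from compound 1 to compound 3 (0.36 log units; beyond the scatter) lies beyond the scatter, while a 1.8-fold higher number from compound 2 to compound 3 (0.26 log units; within the scatter) does not. The untested compound 4, `CN(C)CCCCOC(=O)Nc1ccc(Cn2nc(-c3ccccc3C#N)c3ccccc3c2=O)cc1`, differs from compound 3 by 2-cyanophenyl in place of 4-cyanophenyl on an aromatic carbon.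

Going by the values given here, none of the measured steps concerns this change: a 1.3-fold higher number from compound 1 to compound 2 (0.10 log units; within the scatter) and a 2.3-fold higher number from compound 1 to compound 3 (0.36 log units; beyond the scatter) each add a group to the phenyl, and a 1.8-fold higher number from compound 2 to compound 3 (0.26 log units; within the scatter) swaps one group for another on the same carbon, whereas compound 3 and compound 4 carry the same nitrile on the same ring with the atoms joined differently. The spread across all three measured compounds is modest, and compound 4 keeps every atom of compound 3. It is therefore expected that compound 4 shows a step of a 1.2-fold lower number from compound 3 to compound 4 (0.09 log units; within the scatter), that is, no change beyond the scatter in this assay.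

The estimate for compound 4 in this assay is 30000 nM, with a range from 14000 nM to 65000 nM.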

Compound 4, half-maximal cytotoxic concentration: 90700 nM
Estimate against measurement, compound 4: 3.0-fold (0.48 log units) below; the measured number lies above the stated range.
By their numbers in this assay, from the lowest: compounds 1, 2 and 3 (each within the scatter of the next, the first and the last beyond it); then compound 4.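

In this assay, for the compounds shown here, the place of the nitrile on the pendant phenyl counts by itself: with the same atoms joined differently, 2-cyanophenyl in place of 4-cyanophenyl gives a 2.5-fold higher number from compound 3 to compound 4 (0.39 log units; beyond the scatter) and so a step beyond the scatter, which the earlier compounds could not show as they carry a group only in the 4-substituted form or none at all. Compound 4 also stands clear of the other two compounds, with a 4.5-fold higher number from compound 2 to compound 4 (0.65 log units; beyond the scatter) and with a 5.7-fold higher number from compound 1 to compound 4 (0.75 log units; beyond the scatter) as well, which makes it the compound with the lowest toxicity of the four in this test. Nothing shown here accounts for this difference between the two nitrile isomers.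

The compounds shown leave open whether the higher number belongs to the nitrile or would also follow a chlorine or a methyl group in the place the nitrile holds in compound 4. They also leave open whether the same order of the four compounds would hold in any other cell line.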